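Removing the aryl methyl from compound 1

The compounds below may be only part of what the source reports. "The series", "measured", "known", "first", "only" and "open" are said of these compounds alone.

- compound 1 `Cc1ccccc1Nc1nc(Nc2ccc(N3CCN(C)CC3)cn2)ncc1Cl`: 7470 nM
- compound 2 `Cc1ccccc1Nc1nc(Nc2ccc(N3CCNCC3)cn2)ncc1Cl`: 5060 nM
- compound 3 `Cc1ccccc1Nc1nc(Nc2ccc(N3CCCCC3)cn2)ncc1Cl`: > 100000 nM (a limit)

All three compounds were read in a functional assay on MDA-MB-231 cells (Homo sapiens) for inhibition, read by CCK-8 assay, with a stated time of 48 h; a higher number here means a weaker inhibitor of growth, a lower number a stronger inhibitor of growth. Compound 1 and compound 2 lie within the scatter of each other, with a 1.5-fold lower number from compound 1 to compound 2 (0.17 log units; within the scatter). Compound 3 gave only a limit.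

The next compound is compound 4 `CN1CCN(c2ccc(Nc3ncc(Cl)c(Nc4ccccc4)n3)nc2)CC1`, which keeps the 4-methylpiperazin-1-yl group of compound 1 and differs by hydrogen in place of methyl on an aromatic carbon, turning 2-methylphenyl into phenyl. For the measured compounds named here, no measured step changes this group. The large steps, an at least 13-fold higher number from compound 1 to compound 3 (1.12 log units; beyond the scatter) and an at least 19-fold higher number from compound 2 to compound 3 (1.29 log units; beyond the scatter), both bring in piperidin-1-yl and cannot be carried over. The loss of a methyl elsewhere in the series, a 1.5-fold lower number from compound 1 to compound 2 (0.17 log units; within the scatter), stayed within the scatter, but it sits on an amine nitrogen in a ring and is only a weak guide. No step beyond the scatter is therefore expected, though the range is kept wide. The expected step is a 1.1-fold lower number from compound 1 to compound 4 (0.03 log units; within the scatter). The estimated value for compound 4 is 7000 nM, within an expected range of 2000 nM to 25000 nM.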

Compound 4, concentration for 50% growth inhibition: 37400 nM
For compound 4 the middle estimate is 5.3-fold (0.73 log units) below the measured one; measured number above the stated range.
By their numbers in this assay, from the lowest: compounds 2 and 1 (each within the scatter of the next); then compound 4. At a limit, above all of these: compound 3.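

In this assay the methyl of the 2-methylphenyl group counts: hydrogen in its place on this aromatic carbon gives a 5.0-fold higher number from compound 1 to compound 4 (0.70 log units; beyond the scatter) and so a first measured change away from the piperazine end of the series. The other methyl loss in the series, on an amine nitrogen in a ring, gives a 1.5-fold lower number from compound 1 to compound 2 (0.17 log units; within the scatter) and so does not show the same sensitivity. The step here is modest, and nothing measured for these compounds gives a reason for it.

As far as these compounds go, what a chloro, methoxy or ethyl group would give in place of this methyl remains open. Also open, from the compounds shown here alone, is whether 2-methylphenyl to phenyl would give a step of like size with the piperazin-1-yl group of compound 2.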